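Adding a Dimethylamino Group to the Core of Compound 1

This account rests on a few compounds, and the source may have more. Where it says the series, first, only, none or still open, it means among the compounds named here.

Among the compounds with values here, compound 1 `O=C(NS(=O)(=O)c1ccccc1)n1ccc2cccnc21` gives 4500 nM in an assay on COS7 cells for inhibition of Ectonucleotide pyrophosphatase/phosphodiesterase family member 1 (Homo sapiens), with a stated time of 35 min (a lower number here means a stronger inhibitor, a higher number a weaker inhibitor), the lowest of the two numbers so far; compound 2 `O=C(NS(=O)(=O)c1ccc(Cl)cc1)n1ccc2cccnc21` gives 10400 nM in this assay, and a 2.3-fold higher number from compound 1 to compound 2 (0.36 log units; beyond the scatter). Compound 3 `CN(C)c1ccnc2c1ccn2C(=O)NS(=O)(=O)c1ccccc1` carries dimethylamino in place of hydrogen on an aromatic carbon, on the six-membered aromatic ring of the shared core. Within the data shown here, the one measured step alters the sulfonyl-bearing ring, not this ring, so it does not bear on the change, and no step beyond a modest one in either direction is expected. Compound 3 is estimated at 3500 nM, within 900 nM to 14000 nM. This expected step is a 1.3-fold lower number from compound 1 to compound 3 (0.11 log units; within the scatter).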

Compound 3, half-maximal inhibitory concentration: 2770 nM
For compound 3 the middle estimate is 1.3-fold (0.10 log units) above the measured one; measured number inside the range.
By their numbers in this assay, from the lowest: compounds 3 and 1 (each within the scatter of the next); then compound 2.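

In this assay, dimethylamino in place of hydrogen on an aromatic carbon of the six-membered ring, opposite the ring nitrogen, gives a 1.6-fold lower number from compound 1 to compound 3 (0.21 log units; within the scatter) and so stays within repeat-measurement variation. Within the data shown here, this is the first view of a change on the shared core, and this position accepts dimethylamino without a clear shift in the number. Nothing available explains this result.

On these data alone, whether an amino group, a methoxy group or a longer chain here would shift the number beyond the scatter remains open. Also open, as far as these compounds go, is whether chloro on the sulfonyl-bearing ring acts the same alongside dimethylamino.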